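A few compounds are considered here, and "the series" means these few. Any claim that something is new, unique, unknown or untested is made for them only; others in the source may bear on it.

Measured in a functional assay on MDA-MB-231 cells (Homo sapiens), read by microscopy and transwell migration, with a stated time of 24 h; a higher number here means a weaker inhibitor, a lower number a stronger inhibitor:
- Compound 1 `COc1ccc(C(=O)N(C)c2nc(-c3cc(OC)c(OC)c(OC)c3)cs2)cc1`: 312 nM
- Compound 2 `COc1ccccc1C(=O)N(C)c1nc(-c2cc(OC)c(OC)c(OC)c2)cs1`: > 25000 nM

Compound 2 gives only a limit, > 25000 nM, and so stands with no number of its own. Compound 3 `COc1cccc(C(=O)N(C)c2nc(-c3cc(OC)c(OC)c(OC)c3)cs2)c1` differs from it as follows: 3-methoxyphenyl in place of 2-methoxyphenyl on a carbonyl carbon, with 3-methoxyphenyl in place of 2-methoxyphenyl on a carbonyl carbon. Going by the values given here, the one measured step that bears on this is large: an at least 80-fold higher number from compound 1 to compound 2 (1.90 log units; beyond the scatter), with 2-methoxyphenyl in place of 4-methoxyphenyl. Removing 2-methoxyphenyl is therefore expected to bring a large step to a lower number in this assay, probably not all the way to the value of compound 1 at 312 nM. The estimate means an expected at least 16-fold lower number from compound 2 to compound 3 (1.22 log units; beyond the scatter). For compound 3 the estimated value is 1500 nM, with an expected range of 250 nM to 12000 nM.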

Compound 3, half-maximal inhibitory concentration: 646 nM
The estimate for compound 3 lay 2.3-fold (0.37 log units) above the measured number; low and high end bracket the measured number.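

In this assay, the sharp loss belongs to 2-methoxyphenyl alone and does not follow from any departure from 4-methoxyphenyl: 3-methoxyphenyl on the carbonyl carbon gives an at least 38-fold lower number from compound 2 to compound 3 (1.58 log units; beyond the scatter). Set against 4-methoxyphenyl, the same group costs far less, with a 2.1-fold higher number from compound 1 to compound 3 (0.32 log units; beyond the scatter), a modest step though beyond the scatter. The first of these steps is a bound, not an exact size, and it rests on a limit for compound 2: the limit of > 25000 nM in this assay, at which 1 of the 3 values shown sits.

From the compounds shown here alone, whether a plain phenyl would hold this level remains open. So does whether a hydroxyl or an amine could replace the methoxy group.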